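Working notes: from compound 1 to compound 4

The source may report more compounds than this note shows. Statements on the series, on what has been measured and on what is new or still open speak of the compounds shown alone.

- compound 1 (`COc1ccc(CCC[C@H]2C[C@@H]([C@@H](O)c3ccc(OC)c(OC)c3)CO[C@@H]2c2ccc(OC)c(OC)c2)cc1OC`) gives 37700 nM
- compound 2 (`COc1ccc([C@@H]2OC[C@H]([C@@H](O)c3ccc(OC)c(OC)c3)C[C@H]2C/C=C/c2ccc(OC)c(OC)c2)cc1`) gives 29200 nM
- compound 3 (`COc1ccc([C@H](O)[C@H]2CO[C@H](c3ccc(OC)c(OC)c3)[C@@H](C/C=C/c3ccc(OC)c(OC)c3)C2)cc1`) gives 46000 nM

These values come from a functional assay on HeLa cells (Homo sapiens) for cytotoxicity, read by WST assay, with a stated time of 48 h (a higher number here means a weaker inhibitor, a lower number a stronger inhibitor), and compound 1 stands within the scatter of both compound 2 and compound 3. Compound 4 (`COc1ccc(/C=C/C[C@H]2C[C@@H]([C@@H](O)c3ccc(OC)c(OC)c3)CO[C@@H]2c2ccc(OC)c(OC)c2)cc1`) is not yet measured and departs from compound 1 by 2-(4-methoxyphenyl)ethenyl in place of 2-(3,4-dimethoxyphenyl)ethyl on a saturated chain carbon bound to a saturated ring carbon on a saturated chain carbon bound to a saturated ring carbon. Among the compounds with values here, no measured pair isolates this change. Compound 2 and compound 3 also carry a double bond outside aromatic rings, and their values stay close to that of compound 1, so no step beyond the scatter is expected in this assay here. The expected 1.1-fold lower number from compound 1 to compound 4 (0.03 log units; within the scatter) stays within the scatter. Compound 4 is estimated at 35000 nM with an expected range of 15000 nM to 80000 nM for now.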

Compound 4, half-maximal inhibitory concentration: 12200 nM
Compound 4: the middle estimate sits 2.9-fold (0.46 log units) above what was measured, and the stated range ends above it.
By their numbers in this assay, from the lowest: compound 4; then compounds 2, 1 and 3 (each within the scatter of the next).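

Within the data shown here, at this position, on a saturated chain carbon bound to a saturated ring carbon, 2-(4-methoxyphenyl)ethenyl in place of 2-(3,4-dimethoxyphenyl)ethyl gives a 3.1-fold lower number from compound 1 to compound 4 (0.49 log units; beyond the scatter) in this assay and so shows a change here moving the read-out beyond the scatter, which the earlier compounds did not show. The change alters the chain and the aromatic ring at once, so neither part is isolated. No evidence at hand explains this step.

On these data alone, whether the double bond or the lost methoxy carries the step stays open. Also open, as far as these compounds go, is how a longer saturated chain or an amine in place of this group would read.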